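A few compounds are considered here, and "the series" means these few. Any claim that something is new, unique, unknown or untested is made for them only; others in the source may bear on it.

In an in vitro functional assay on HEK285-7 cells for antagonist activity at prostaglandin D2 receptor 2 (Homo sapiens), read by BRET and beta-arrestin recruitment (a higher number here means a larger maximal response, a lower number a smaller maximal response), three compounds have been measured:

- compound 1 `O=C(O)Cc1sc(C(c2ccc(F)cc2)c2ccc(F)cc2)nc1-c1ccnc(F)c1`: 80%
- compound 2 `O=C(O)Cc1sc(C(c2ccc(F)cc2)c2ccc(F)cc2)nc1-c1ccoc1`: 80%
- compound 3 `NS(=O)(=O)c1ccc(-c2nc(C(c3ccc(F)cc3)c3ccc(F)cc3)sc2CC(=O)O)cc1`: 80%

Compound 3 stands level with compounds 1 and 2 at the digits shown; its nearest neighbour is compound 1 and its furthest is compound 2, and neither gap reaches beyond the scatter. Compound 4 `NS(=O)(=O)c1cccc(-c2nc(C(c3ccc(F)cc3)c3ccc(F)cc3)sc2CC(=O)O)c1` is the next compound, and it differs from compound 3 in one place: 3-sulfamoylphenyl in place of 4-sulfamoylphenyl on an aromatic carbon. The steps measured so far all exchange the whole group on this aromatic carbon and were no change at the digits printed from compound 1 to compound 2 (within the scatter), no change at the digits printed from compound 1 to compound 3 (within the scatter) and no change at the digits printed from compound 2 to compound 3 (within the scatter). None of them exchanges a 4-sulfamoylphenyl for a 3-sulfamoylphenyl, so the bearing is indirect, but since three unrelated groups here gave no step beyond the scatter, no step beyond the scatter is expected: no change at the digits printed from compound 3 to compound 4 (within the scatter). Compound 4 is therefore estimated at 80%, within 65% to 95%.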

Compound 4, largest response reached (reported as efficacy), in percent of the reference or control that the assay uses: 55%
Compound 4: the middle estimate sits 25 percentage points above what was measured; the measured number lies below the stated range.
By their numbers in this assay, from the lowest: compound 4; then compounds 1, 2 and 3 (each within the scatter of the next).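

In this assay, compounds with the same atoms, joined differently, gave a number 25 percentage points lower from compound 3 to compound 4 (beyond the scatter), so at this aromatic carbon the place of the sulfamoyl group on the phenyl ring matters, which the exchanges of whole groups had not revealed. The 3-sulfamoylphenyl group also stands apart from the other groups, with a number 25 percentage points lower from compound 2 to compound 4 (beyond the scatter) and a number 25 percentage points lower from compound 1 to compound 4 (beyond the scatter). No evidence available here bears on this result. From the compounds shown here alone, it remains open whether the step is specific to the sulfamoyl group, or whether a 3-aminophenyl or 3-carboxyphenyl group would behave in the same way.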